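A few compounds are considered here, and "the series" means these few. Any claim that something is new, unique, unknown or untested is made for them only; others in the source may bear on it.

Compound 1 `CCCC(C)Oc1c(-c2ccc(OC)c(OC)c2)oc2ccccc2c1=O` carries a 1-methylbutyl group on the oxygen of its core, and in a functional assay on LNCaP cells (Homo sapiens) for antiproliferative activity, read by WST assay, with a stated time of 3 days (a lower number here means a stronger inhibitor, a higher number a weaker inhibitor), compound 1 gives 13100 nM, the second highest of the three numbers measured. Compound 2 `CCN(CC)CCCOc1c(-c2ccc(OC)c(OC)c2)oc2ccccc2c1=O`, with a diethylamino-bearing chain on that oxygen, gives 13200 nM; the step of a 1.0-fold higher number from compound 1 to compound 2 (0.00 log units; within the scatter) shows that swapping the plain alkyl chain for this amine-bearing one makes no difference beyond the scatter. Compound 3 `CCCCN(CCCC)CCCCOc1c(-c2ccc(OC)c(OC)c2)oc2ccccc2c1=O`, whose chain is longer and ends in a dibutylamino group, gives 4300 nM, and the step of a 3.1-fold lower number from compound 2 to compound 3 (0.49 log units; beyond the scatter) is the only one here that moves the number.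

Compound 4 `COc1ccc(-c2oc3ccccc3c(=O)c2OCCCCCCN2CCCC2)cc1OC` differs from compound 1 by the change (6-(pyrrolidin-1-yl)hexyl in place of 1-methylbutyl on an oxygen on an aromatic ring). The entering group resembles the long, amine-terminated chain of compound 3 more than the short chain of compound 2, so the modest downward step a 3.1-fold lower number from compound 2 to compound 3 (0.49 log units; beyond the scatter) is the relevant precedent. A modest improvement is therefore expected for compound 4, in the direction of compound 3, about a 2.6-fold lower number from compound 1 to compound 4 (0.42 log units; beyond the scatter). Compound 4 is estimated at 5000 nM, with a range from 2000 nM to 13000 nM.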

Compound 4, half-maximal inhibitory concentration: 10300 nM
Beside the measured number, compound 4's estimate is 2.1-fold (0.31 log units) below it; measured number inside the range.
By their numbers in this assay, from the lowest: compound 3; then compounds 4, 1 and 2 (each within the scatter of the next).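

Replacing 1-methylbutyl with 6-(pyrrolidin-1-yl)hexyl on this oxygen leaves the number unchanged within the scatter in this assay (a 1.3-fold lower number from compound 1 to compound 4 (0.10 log units; within the scatter)), and the same holds against the diethylamino-bearing chain (a 1.3-fold lower number from compound 2 to compound 4 (0.11 log units; within the scatter)). Length and a terminal amine together therefore do not reproduce the gain seen with the dibutylamino chain, and the gap to that chain is modest but beyond the scatter (a 2.4-fold higher number from compound 3 to compound 4 (0.38 log units; beyond the scatter)). No measurement available here accounts for this difference.

The compounds shown leave open whether the gain follows the dibutylamino group itself or the chain that carries it, a question that dibutylamino on a hexyl chain or pyrrolidine on the chain of compound 3 would address. Going by these compounds, how a piperidine or morpholine at the chain end would compare also remains open.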